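Amine nitrogen substituent: from compound 3 to compound 4

This account rests on a few compounds, and the source may have more. Where it says the series, first, only, none or still open, it means among the compounds named here.

Three compounds share one core and differ in the group on the amine nitrogen: compound 1 `C[C@@H](Cn1ccc(-c2ccc(C#N)c(Cl)c2)n1)NS(=O)(=O)c1cn(C)cn1`, compound 2 `C[C@@H](Cn1ccc(-c2ccc(C#N)c(Cl)c2)n1)Nc1cccnc1` and compound 3 `C[C@@H](Cn1ccc(-c2ccc(C#N)c(Cl)c2)n1)Nc1ncccn1`. In a functional assay on VCaP cells (Homo sapiens) for antiproliferative activity, read by CCK-8 assay, with a stated time of 6 days (on this read-out lower numbers stand for stronger inhibition and higher numbers for weaker inhibition), compound 1 gives 13600 nM. Compound 2 gives > 30000 nM, which is a limit of the assay and not a number. Compound 3 gives 480 nM, the lower of the two actual numbers in the set.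

Compound 4 `C[C@@H](Cn1ccc(-c2ccc(C#N)c(Cl)c2)n1)Nc1ncnc2nc[nH]c12` changes the same place: a group of 9 heavy atoms (5 carbon, 4 nitrogen; one five-membered aromatic ring with 2 hetero atoms, one six-membered aromatic ring with 2 hetero atoms) in place of a group of 6 heavy atoms (4 carbon, 2 nitrogen; one six-membered aromatic ring with 2 hetero atoms), on an amine nitrogen. The entering group keeps one six-membered aromatic ring with 2 hetero atoms and also has one five-membered aromatic ring with 2 hetero atoms.

Within the data shown here, three measured steps bear on this change, all at this amine nitrogen. Two are large: a 28-fold lower number from compound 1 to compound 3 (1.45 log units; beyond the scatter) and an at least 62-fold lower number from compound 2 to compound 3 (1.79 log units; beyond the scatter). The third is at least modest: an at least 2.2-fold higher number from compound 1 to compound 2 (0.34 log units; beyond the scatter). Thus this assay responds strongly to the group at this place, yet none of the three compounds carries a group with two rings. Compound 3 holds the best measured number, so a moderate move to a higher number is expected, with a wide margin given an at least 62-fold lower number from compound 2 to compound 3 (1.79 log units; beyond the scatter). The estimated step is a 2.1-fold higher number from compound 3 to compound 4 (0.32 log units; beyond the scatter). Compound 4 is expected at 1000 nM, with an estimated range of 130 nM to 8000 nM.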

Compound 4, half-maximal inhibitory concentration: 640 nM
Estimate against measurement, compound 4: 1.6-fold (0.19 log units) above; measured number inside the range.
By their numbers in this assay, from the lowest: compounds 3 and 4 (each within the scatter of the next); then compound 1. At a limit, above all of these: compound 2.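

In this assay the amine nitrogen accepts a group with two rings: a 1.3-fold higher number from compound 3 to compound 4 (0.12 log units; within the scatter), so the added five-membered aromatic ring and the hydrogen-bond donor leave compound 3 and compound 4 indistinguishable. The two-ring group also stays well apart from the other groups at this place, with a 21-fold lower number from compound 1 to compound 4 (1.33 log units; beyond the scatter) and an at least 46-fold lower number from compound 2 to compound 4 (1.67 log units; beyond the scatter), so both compounds whose groups contain a six-membered aromatic ring with 2 hetero atoms lie far from compound 1 and compound 2, although compound 2 also carries a six-membered aromatic ring. The value of compound 2 is a limit of the assay and not a number: the limit of > 30000 nM in this assay, at which 1 of the 4 values shown sits.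

The compounds shown leave open whether the five-membered ring can carry further substitution, for example a methyl on its hydrogen-bearing nitrogen, which would remove the donor that enters with compound 4. Also open, going by these compounds, is how a small substituent on the pyrimidin-2-yl ring itself, such as an amine or a carboxylic acid, would read in this assay, and whether any group at this place can reach a number clearly lower than those of compound 3 and compound 4.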